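Swapping Allyl for Methyl on a Shared Core

This account rests on a few compounds, and the source may have more. Where it says the series, first, only, none or still open, it means among the compounds named here.

Compound 2 `C=CCn1nc(Cc2ccc(OC)cc2)c2ccccc2c1=O` has no result in a functional assay on aorta with Alpha-1D adrenergic receptor (Rattus norvegicus) as the target; on this read-out lower numbers stand for an effect already at smaller amounts and higher numbers for an effect only at larger amounts of compound; compound 2 gives "not determined" (no result reported). Its close relative compound 1 `C=CCn1nc(Cc2ccc(SC)cc2)c2ccccc2c1=O` reached only a limit of this assay, and compound 1 gives > 100000 nM. Compound 1 thus stands at the limit of > 100000 nM in this assay, at which 1 of the 2 values shown sits. Compound 3 `COc1ccc(Cc2nn(C)c(=O)c3ccccc23)cc1` differs from compound 2 by hydrogen in place of vinyl on a saturated chain carbon bound to an aromatic nitrogen. For the measured compounds named here, with no measured step between compounds to lean on, this change is expected to move this assay by nothing beyond the usual scatter. Compound 3 is therefore expected to give about 150000 nM, within 30000 nM to 1000000 nM, most likely again reported only as a limit.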

Compound 3, half-maximal effective concentration: < 100000 nM
Compound 3: no number, only a limit; the forecaster's own chance of this, stated with the estimate: 80%; middle value at least 1.5-fold (0.17 log units) from the limit.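

For the compounds shown here, compound 3 gives only a limit, < 100000 nM, and compound 2 has no result, so no step from allyl to methyl can be read. Going by these compounds, what this swap does in this assay therefore stays open.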